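Shortening the chain of compound 1

The source may report more compounds than this note shows. Statements on the series, on what has been measured and on what is new or still open speak of the compounds shown alone.

For the measured compounds named here, in a functional assay on NCI-H460 cells (Homo sapiens) for cytotoxicity (a lower number here means a stronger inhibitor, a higher number a weaker inhibitor), compound 1 `O=C(CCCCCCC(=O)Nc1nc2ccccc2s1)NO` gives 5.71 ug/mL, the higher of the two numbers so far, and compound 2 `Cc1ccc2nc(NC(=O)CCCCCCC(=O)NO)sc2c1` gives 0.84 ug/mL. Compound 3 `O=C(CCCCC(=O)Nc1nc2ccccc2s1)NO` differs from compound 1 by hydroxycarbamoyl in place of 2-(hydroxycarbamoyl)ethyl on a saturated chain carbon, four bonds along the chain from a carbonyl carbon. Going by the values given here, the only measured step, a 6.8-fold lower number from compound 1 to compound 2 (0.83 log units; beyond the scatter), is methyl in place of hydrogen on an aromatic carbon, so it serves only as a rough guide to size. No change to the chain has been measured. A somewhat smaller move toward a higher number is expected, namely a 2.6-fold higher number from compound 1 to compound 3 (0.42 log units; beyond the scatter). The estimated value for compound 3 is 15 ug/mL, within a range of 5 ug/mL to 45 ug/mL.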

Compound 3, half-maximal inhibitory concentration: 14.4 ug/mL
Estimate against measurement, compound 3: 1.0-fold (0.02 log units) above; low and high end bracket the measured number.
By their numbers in this assay, from the lowest: compound 2; then compound 1; then compound 3.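

The chain is now shown to matter in this assay, not only the aromatic carbon changed in the earlier step: hydroxycarbamoyl in place of 2-(hydroxycarbamoyl)ethyl gives a 2.5-fold higher number from compound 1 to compound 3 (0.40 log units; beyond the scatter). Shortening on this saturated chain carbon therefore moves the number up, in the one pair measured. No measured evidence here accounts for this step. The compounds shown leave open whether a longer chain would lower the number, and whether a carboxylic acid could stand in place of hydroxycarbamoyl. Also open, from the compounds shown here alone, is whether methyl on the aromatic carbon gives a similar step on the shorter chain of compound 3.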